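Changing the Substituted Benzyl Group on a Shared Core

A few compounds are considered here, and "the series" means these few. Any claim that something is new, unique, unknown or untested is made for them only; others in the source may bear on it.

Of the compounds shown here, three with one shared core have been measured in an assay on isolated protein for inhibition of serine/threonine-protein kinase PAK 4 (Homo sapiens), read by HTRF, with a stated time of 60 min; on this read-out higher numbers stand for weaker inhibition and lower numbers for stronger inhibition. Compound 1 `Cc1cc(Nc2nc(Cl)nc3[nH]ncc23)n[nH]1` gives 5940 nM. Compound 2 `Cc1cc(Nc2nc(NC3CCNC3)nc3[nH]ncc23)n[nH]1` gives 1050 nM, after the step of a 5.7-fold lower number from compound 1 to compound 2 (0.75 log units; beyond the scatter). Compound 3 `Cc1cc(Nc2nc(NCc3ccccc3Cl)nc3[nH]ncc23)n[nH]1` gives 668 nM; it holds the lowest of the three numbers, clearly apart from compound 1 but not from compound 2, since a 1.6-fold lower number from compound 2 to compound 3 (0.20 log units; within the scatter). Compound 4 `Cc1cc(Nc2nc(NCc3cccc(Br)c3)nc3[nH]ncc23)n[nH]1` differs from compound 3 only by 3-bromophenyl in place of 2-chlorophenyl on a saturated chain carbon bound to a nitrogen on an aromatic ring. Among the compounds with values here, no measured step swaps one benzyl group for another, and the only step that brought in a benzyl group, a 1.6-fold lower number from compound 2 to compound 3 (0.20 log units; within the scatter), stayed within the scatter. The step of a 1.0-fold higher number from compound 3 to compound 4 (0.02 log units; within the scatter) is therefore expected to stay within the scatter too. Compound 4 is estimated at 700 nM in this assay, with a range from 250 nM to 2000 nM.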

Compound 4, half-maximal inhibitory concentration: 4340 nM
Compound 4: middle estimate off by 6.2-fold (0.79 log units), on the low side, outside the stated range (above it).
By their numbers in this assay, from the lowest: compounds 3 and 2 (each within the scatter of the next); then compounds 4 and 1 (each within the scatter of the next).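

The group on this saturated chain carbon clearly matters: 3-bromophenyl in place of 2-chlorophenyl gives a 6.5-fold higher number from compound 3 to compound 4 (0.81 log units; beyond the scatter), although both groups have the same heavy-atom count. A benzyl group is therefore not interchangeable with pyrrolidin-3-yl in every form, since 3-bromobenzyl in its place gives a 4.1-fold higher number from compound 2 to compound 4 (0.62 log units; beyond the scatter), while 2-chlorobenzyl stayed within the scatter. No measurement at hand explains this difference.

The step changes both the halogen and its ring position, so the compounds shown leave open which of the two matters. A 3-chlorophenyl group would separate them.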